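Epimer of a Weakly Cytotoxic Ester: Compound 4

The compounds below may be only part of what the source reports. "The series", "measured", "known", "first", "only" and "open" are said of these compounds alone.

This set of three measured compounds comes from a study of a functional assay on SEM cells (Homo sapiens) for cytotoxicity, read by MTT assay, with a stated time of 72 h; on this read-out lower numbers stand for stronger inhibition and higher numbers for weaker inhibition. Compound 1 `COc1ccc(C(=O)OCC2=CC[C@@]3(C)CCC(C(C)C)=C3CC2)cc1` gives 25500 nM, while compound 3 `C/C=C(/C)C(=O)O[C@H]1CC(C)=C[C@@H](OC(=O)/C(C)=C\C)[C@@]2(C)CC[C@@](O)(C(C)C)[C@H]12` gives 2400 nM. Compound 2 `COc1ccc(C(=O)O[C@H]2CC(C)=C[C@H](O)[C@@]3(C)[C@@H](OC(C)=O)C[C@@](O)(C(C)C)[C@H]23)cc1` gives 18100 nM, the second highest of the three numbers; it sits within the scatter of compound 1 and well above compound 3. The unmeasured compound 4 `COc1ccc(C(=O)O[C@H]2CC(C)=C[C@@H](O)[C@@]3(C)[C@@H](OC(C)=O)C[C@@](O)(C(C)C)[C@H]23)cc1` differs from compound 2 only as follows: the two compounds have the same atoms and bonds and differ only in configuration as drawn: 1 of 6 stereo elements differ; a stereocentre at a saturated ring carbon is drawn S in compound 2 and R in compound 4. Within the data shown here, no measured pair shows what such a change does here, so the step from compound 2 to compound 4 in this assay is expected to be small, in either direction, and likely within the scatter. Compound 4 is therefore estimated at 20000 nM, with a range of 6000 nM to 60000 nM, which means an expected step of a 1.1-fold higher number from compound 2 to compound 4 (0.04 log units; within the scatter).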

Compound 4, half-maximal inhibitory concentration: > 100000 nM
Compound 4 gave a limit, no number; the forecaster's own chance of this, stated with the estimate: 15%; middle value at least 5.0-fold (0.69 log units) from the limit.
By their numbers in this assay, from the lowest: compound 3; then compounds 2 and 1 (each within the scatter of the next). At a limit, above all of these: compound 4.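

Among these compounds, changing a single saturated ring carbon from S to R gives an at least 5.5-fold higher number from compound 2 to compound 4 (0.74 log units; beyond the scatter) in this assay, so the drawn configuration at this position matters, which no earlier pair could show. Compound 4 reads > 100000 nM, which is a limit of the assay and not a number. The step can be traced to this one stereocentre, because nothing else changes: the fact that compounds 2 and 4 differ only in the configuration as drawn.

Still open, going by these compounds, is whether the other stereo elements matter as much. On these data alone, it is also open whether an amine or a methyl ether in place of the hydroxyl group of compounds 2 and 4 would show the same dependence on configuration.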